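Nitro in Place of Dimethylamino: What to Expect

This account rests on a few compounds, and the source may have more. Where it says the series, first, only, none or still open, it means among the compounds named here.

Measured in a functional assay on HT-29 cells (Homo sapiens) for cytotoxicity, read by sulforhodamine B assay; a lower number here means a stronger inhibitor of growth, a higher number a weaker inhibitor of growth:
Compound 1 `COc1ccc(/C=N\NC(=S)NC(C)(C)CCC[C@](C)(O)[C@@H]2CC=C(C)CC2)cc1`: 35200 nM
Compound 2 `CC1=CC[C@@H]([C@@](C)(O)CCCC(C)(C)NC(=S)N/N=C\c2ccc(N(C)C)cc2)CC1`: > 100000 nM (a limit of the assay)

Compound 2 has no exact number, since > 100000 nM is only a limit of the assay. Compound 3 `CC1=CC[C@@H]([C@@](C)(O)CCCC(C)(C)NC(=S)N/N=C\c2ccc([N+](=O)[O-])cc2)CC1` keeps the same core and changes one group: nitro in place of dimethylamino on an aromatic carbon. The group sits on an aromatic carbon, para to a large group. Within the data shown here, one measured step touches this place, an at least 2.8-fold higher number from compound 1 to compound 2 (0.45 log units; beyond the scatter), and it lies beyond the scatter. Among the measured compounds shown here, it is the only evidence here, and no measured compound carries nitro. Compound 2 alone holds dimethylamino, so removing that group is expected to lower the number in this assay by a modest amount. The expected change is an at least 2.5-fold lower number from compound 2 to compound 3 (0.39 log units; beyond the scatter). For compound 3 the estimated value is 40000 nM, with an expected range of 12000 nM to 100000 nM.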

Compound 3, concentration for total growth inhibition: 62800 nM
Compound 3: the middle estimate sits 1.6-fold (0.20 log units) below what was measured; measured number inside the range.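

In this assay, nitro in place of dimethylamino gives an at least 1.5-fold lower number from compound 2 to compound 3 (0.20 log units; that floor lies within the scatter), and a floor of that size does not establish a real difference between these two groups. Nitro in place of methoxy gives a 1.8-fold higher number from compound 1 to compound 3 (0.25 log units; within the scatter), which means that these two groups, on the same aromatic carbon, cannot be told apart here, and this comparison was not available from the earlier compounds. Going by these compounds, the true size of the step from dimethylamino to nitro stays unknown, since compound 2 carries a limit and not a number: the limit of > 100000 nM in this assay, at which 1 of the 3 values shown sits.

On these data alone, whether a group on this carbon can take the number beyond the scatter in the lower direction remains open. A carboxylic acid, a primary amine or a chlorine atom at this place could each answer that, and none of them appears among the compounds shown.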